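The source may hold more compounds than are shown below. What is called first, only, known or untested is meant among the compounds shown, and "the series" means these compounds.

Measured in an ADME assay on cells (Homo sapiens) for cytotoxicity, read by resazurin assay, with a stated time of 5 days; on this read-out lower numbers stand for higher toxicity in this test and higher numbers for lower toxicity in this test:
- Compound 1 `COc1ccc(-c2nc(/C=C\c3cccc(Cl)c3)nc3ccsc23)cn1`: 53000 nM
- Compound 2 `COc1ccc(-c2nc(C(C)S(=O)(=O)c3cccc(Cl)c3)nc3ccsc23)cn1`: > 50000 nM, a limit
- Compound 3 `COc1ccc(-c2nc(CS(=O)(=O)c3cccc(Cl)c3)nc3ccsc23)cn1`: > 10000 nM, a limit

Compound 3 stands only at a limit, > 10000 nM, and no number is known for it. Removing the methyl of compound 2 is a step that the two limits leave unreadable from compound 2 to compound 3. Compound 4 `O=S(=O)(Cc1nc(-c2cccs2)c2sccc2n1)c1cccc(Cl)c1` carries thiophen-2-yl in place of 6-methoxypyridin-3-yl on an aromatic carbon, (thiophen-2-yl in place of 6-methoxypyridin-3-yl on an aromatic carbon). Among the measured compounds shown here, no measured step covers this change, so no size can be carried over from one. For the measured compounds named here, compound 1, at 53000 nM, gives the only true number, so low toxicity in this assay is expected to persist. The expected step is a step that the limit leaves unreadable from compound 3 to compound 4, a modest one resting on little evidence. For compound 4 the estimated value is 30000 nM, with an expected range of 10000 nM to 90000 nM.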

Compound 4, half-maximal cytotoxic concentration: > 50000 nM
Compound 4 ended at the assay's limit (the forecaster's own chance of this, stated with the estimate: 50%); middle value at least 1.6-fold (0.22 log units) away from the limit.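

Among the compounds shown here, compound 3 and compound 4 both stand only at limits, and no step between them can be read. The compounds shown leave open how thiophen-2-yl and 6-methoxypyridin-3-yl compare in this assay.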